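The source may hold more compounds than are shown below. What is called first, only, known or untested is meant among the compounds shown, and "the series" means these compounds.

Measured compounds in an ADME assay on Vero cells (Chlorocebus sabaeus) for cytotoxicity, read by MTT assay, with a stated time of 48 h; on this read-out higher numbers stand for weaker inhibition and lower numbers for stronger inhibition:
- compound 1 `CS(=O)(=O)NC1CCC(CN2CCN(c3cc(=O)c4cc(C(F)(F)F)cc([N+](=O)[O-])c4s3)CC2)CC1` gives 48.5 ug/mL
- compound 2 `O=c1cc(N2CCN(CC3CCC(NS(=O)(=O)c4ccccc4)CC3)CC2)sc2c([N+](=O)[O-])cc(C(F)(F)F)cc12` is reported only as a limit of the assay, > 64 ug/mL
- compound 3 `O=C(OC1CCC(CN2CCN(c3cc(=O)c4cc(C(F)(F)F)cc([N+](=O)[O-])c4s3)CC2)CC1)c1ccc(F)cc1` is likewise reported only as a limit of the assay, > 64 ug/mL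

Among the measured compounds shown here, compound 1 holds the only actual number in the set; the two other values are limits. The unmeasured compound 4 `O=C(OC1CCC(CN2CCN(c3cc(=O)c4cc(C(F)(F)F)cc([N+](=O)[O-])c4s3)CC2)CC1)c1cccs1` differs from compound 1 in one place: ((thiophen-2-yl)carbonyl)oxy in place of methanesulfonamido on a saturated ring carbon. Two measured steps start from compound 1 and bear on this change: an at least 1.3-fold higher number from compound 1 to compound 2 (0.12 log units; that floor lies within the scatter) and an at least 1.3-fold higher number from compound 1 to compound 3 (0.12 log units; that floor lies within the scatter). Both end at the limit of > 64 ug/mL in this assay, at which 2 of the 3 values shown sit, so each is readable only as a floor, and that floor lies within the scatter. The step that the two limits leave unreadable from compound 2 to compound 3 adds nothing readable. Compound 3 carries an aromatic ester on the same saturated ring carbon as compound 4 does, and it is reported only as a limit. The step to compound 4 is therefore expected to be a 1.5-fold higher number from compound 1 to compound 4 (0.17 log units; within the scatter), most likely ending again at a limit rather than a number. Compound 4 is estimated at 72 ug/mL in this assay, within 45 ug/mL to 120 ug/mL.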

Compound 4, half-maximal inhibitory concentration: > 64 ug/mL
Compound 4 was reported as a limit; the forecaster's own chance of this, stated with the estimate: 70%; the middle value is on the limit's open side.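

In this assay compound 4 is reported only as a limit of the assay, so a second aromatic ester on this saturated ring carbon, after compound 3, again yields no number: the limit of > 64 ug/mL in this assay, at which 3 of the 4 values shown sit. Putting ((thiophen-2-yl)carbonyl)oxy in place of methanesulfonamido gives an at least 1.3-fold higher number from compound 1 to compound 4 (0.12 log units; that floor lies within the scatter), so no real shift can be claimed for this change. The steps from compound 2 and compound 3 to compound 4 cannot be read, which leaves thiophen-2-yl and 4-fluorophenyl on the carbonyl carbon indistinguishable here.

As far as these compounds go, the size of the gap between compound 1 and the three limit compounds remains open. Also open, from the compounds shown here alone, is whether an amine or a carboxylic acid on this saturated ring carbon would give a readable number in this assay.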